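Removing Both Chlorines from the Aryl on the Ring Nitrogen

The source may hold more compounds than are shown below. What is called first, only, known or untested is meant among the compounds shown, and "the series" means these compounds.

Of the compounds shown here, two have been measured in a physicochemical assay; a lower number here means that less compound is needed, a higher number that more compound is needed for the effect. Compound 1, with the structure `COc1cc(/C=N/NC(=O)c2nn(-c3ccc(Cl)cc3Cl)c(-c3ccc(Cl)cc3)c2C)ccc1O`, gives 3550000 nM. Compound 2, with the structure `COc1cc(/C=N/NC(=O)c2nn(-c3ccc(Cl)cc3Cl)c(-c3ccccc3)c2C)ccc1O`, gives 2990000 nM. Within the data shown here, compound 2 therefore holds the lowest of the two numbers, but the only other number is close: a 1.2-fold lower number from compound 1 to compound 2 (0.07 log units; within the scatter), so the two compounds cannot be separated in this assay.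

Compound 3, with the structure `COc1cc(/C=N/NC(=O)c2nn(-c3ccccc3)c(-c3ccccc3)c2C)ccc1O`, has not yet been measured. It differs from compound 2 in one place: phenyl in place of 2,4-dichlorophenyl on an aromatic nitrogen. Among the measured compounds shown here, the only measured step that resembles this change is the one from compound 1 to compound 2, where one chloro was also replaced by hydrogen on an aromatic carbon, and that step stayed within the scatter. Because a 1.2-fold lower number from compound 1 to compound 2 (0.07 log units; within the scatter) was so small, no step beyond the scatter is expected for compound 3 in this assay either, though the direction, if any, would likely be toward a lower number.

Compound 3 is estimated to give 2500000 nM, with a range from 1000000 nM to 6000000 nM. This estimate means a step of a 1.2-fold lower number from compound 2 to compound 3 (0.08 log units; within the scatter) is expected.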

Compound 3, half-maximal effective concentration: 2460000 nM
The estimate for compound 3 lay 1.0-fold (0.01 log units) above the measured number; the range from low to high includes it.
By their numbers in this assay, from the lowest: compounds 3, 2 and 1 (each within the scatter of the next).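

The earlier step changed a single chloro on an aromatic carbon, whereas this one replaces the whole group on the aromatic nitrogen, taking away both chlorines at once. Phenyl in place of 2,4-dichlorophenyl gives a 1.2-fold lower number from compound 2 to compound 3 (0.08 log units; within the scatter) in this assay, so compound 2 and compound 3 cannot be told apart in this assay, and at this nitrogen the loss of both chlorines produces no readable step. No measurement at hand explains this result.

Going by these compounds, the aromatic ring itself stays in place in both compounds, so the result says nothing about the need for a ring at this nitrogen, and whether a group of a different kind, such as a longer chain, an amine or a carboxylic acid, would move the number beyond the scatter remains open. Also open is whether any change at this nitrogen would give a readable step in this assay, since the compounds shown cover only phenyl and 2,4-dichlorophenyl there, and whether the same change would matter in any other kind of assay.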